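The compounds below may be only part of what the source reports. "The series", "measured", "known", "first", "only" and "open" are said of these compounds alone.

Compound 1 `Cc1cc(NC(=O)Cn2nnc(-c3cccnc3)n2)n(C2CCCCC2)n1`: in an assay on HEK293 cells for activation of Kir3.1/Kir3.2 (Homo sapiens), read by thallium flux (a lower number here means that less compound is needed, a higher number that more compound is needed for the effect), compound 1 gives 1930 nM.
Compound 2 `Cc1cc(NC(=O)Cn2nnc(-c3ccc(Cl)c(Cl)c3)n2)n(C2CCCCC2)n1`: compound 2 gives 1220 nM.
Compound 3 `Cc1cc(NC(=O)Cn2nnc(-c3ccccc3F)n2)n(C2CCCCC2)n1`: compound 3 gives 187 nM.

Compound 3 holds the lowest number of the three: the step of a 6.5-fold lower number from compound 2 to compound 3 (0.81 log units; beyond the scatter) and the step of a 10-fold lower number from compound 1 to compound 3 (1.01 log units; beyond the scatter) both lie beyond the scatter, while the step of a 1.6-fold lower number from compound 1 to compound 2 (0.20 log units; within the scatter) does not. Compound 4 `Cc1cccc(-c2nnn(CC(=O)Nc3cc(C)nn3C3CCCCC3)n2)c1` differs from compound 3 in one place: 3-methylphenyl in place of 2-fluorophenyl on an aromatic carbon. Going by the values given here, no measured step exchanges exactly these two groups, but the two steps reaching compound 3 show that the group on this aromatic carbon can move the number by large amounts. Since the 2-fluorophenyl that accompanies the lowest number leaves, compound 4 is expected to give a higher number, with a step of a 3.2-fold higher number from compound 3 to compound 4 (0.51 log units; beyond the scatter). Compound 4 is therefore estimated at 600 nM, in a range from 200 nM to 1800 nM.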

Compound 4, half-maximal effective concentration: 129 nM
Beside the measured number, compound 4's estimate is 4.7-fold (0.67 log units) above it, and the stated range ends above it.
By their numbers in this assay, from the lowest: compounds 4 and 3 (each within the scatter of the next); then compounds 2 and 1 (each within the scatter of the next).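

In this assay, going by these compounds alone, the 2-fluorophenyl is not the only group at the low end: 3-methylphenyl in its place leaves the number level (a 1.4-fold lower number from compound 3 to compound 4 (0.16 log units; within the scatter)), so fluorine is not needed on this aromatic carbon's phenyl. The 3-methylphenyl also stands clearly apart from the two higher groups (a 9.5-fold lower number from compound 2 to compound 4 (0.98 log units; beyond the scatter); a 15-fold lower number from compound 1 to compound 4 (1.17 log units; beyond the scatter)), so two phenyls with a single substituent share the low end. Nothing available here accounts for these differences. From the compounds shown here alone, it remains open whether a methoxy, an amine or a carboxylic acid on the phenyl would keep the number this low.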